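Cytotoxicity of compound 2 and its methyl analogue

A few compounds are considered here, and "the series" means these few. Any claim that something is new, unique, unknown or untested is made for them only; others in the source may bear on it.

- compound 1 `Cc1c(C(C)c2c(F)cccc2F)nc(Nc2ccc(C#N)cc2)[nH]c1=O`: 1060 nM
- compound 2 `Cc1c(N)nc(Nc2ccc(C#N)cc2)nc1Cc1c(F)cccc1F`: 45900 nM
- compound 3 `CC(c1cc(Cl)nc(Nc2ccc(C#N)cc2)n1)c1c(F)cccc1F`: > 2690 nM

All three values come from an ADME assay on MT4 cells (Homo sapiens) for cytotoxicity, read by MTT assay; a higher number here means that more compound is tolerated, a lower number that less compound is tolerated. Compound 3 gives only a limit, > 2690 nM. Of the two numerical values, compound 2 has the higher, beyond the scatter from compound 1. Compound 4 `Cc1c(N)nc(Nc2ccc(C#N)cc2)nc1C(C)c1c(F)cccc1F` has methyl in place of hydrogen on a saturated chain carbon bound to two aromatic carbons. For the measured compounds named here, no measured pair isolates this change, so the expectation is tentative. A moderate fall beyond the scatter is expected, since compound 1 stands at 1060 nM, far under compound 2. The expected change is a 3.1-fold lower number from compound 2 to compound 4 (0.49 log units; beyond the scatter). For compound 4 the estimated value is 15000 nM, with an expected range of 3000 nM to 60000 nM.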

Compound 4, half-maximal cytotoxic concentration: 40500 nM
Estimate against measurement, compound 4: 2.7-fold (0.43 log units) below; the range from low to high includes it.
By their numbers in this assay, from the lowest: compound 1; then compounds 4 and 2 (each within the scatter of the next).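

Methyl in place of hydrogen on a saturated chain carbon bound to two aromatic carbons gives a 1.1-fold lower number from compound 2 to compound 4 (0.05 log units; within the scatter) in this assay. For the compounds shown here, this is the first measured pair to isolate the change, and on this core the two compounds stand level, so this position accepts a methyl without a step beyond the scatter. Nothing measured here bears on why the two stand level.

As far as these compounds go, whether a longer chain such as ethyl, or a hydroxyl, at this carbon would stand level too remains open. So does whether the methyl behaves alike on the core of compound 1.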